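This account rests on a few compounds, and the source may have more. Where it says the series, first, only, none or still open, it means among the compounds named here.

Measured in a functional assay on A549 cells (Homo sapiens) for antiproliferative activity, read by MTT assay, with a stated time of 72 h; on this read-out lower numbers stand for stronger inhibition and higher numbers for weaker inhibition:
compound 1 `CN(c1ccc2[nH]c(-c3n[nH]c4ccccc34)cc2n1)S(=O)(=O)c1ccc(Cl)cc1` gives 18200 nM
compound 2 `COc1ccc(S(=O)(=O)N(C)c2ccc3[nH]c(-c4n[nH]c5ccccc45)cc3n2)c(OC)c1` gives 25900 nM

Compound 2 holds the higher of the two numbers, with compound 1 nearest to it. Going by the values given here, the single measured step, a 1.4-fold higher number from compound 1 to compound 2 (0.15 log units; within the scatter), lies within the scatter. Compound 3 `CN(c1ccc2[nH]c(-c3n[nH]c4ccccc34)cc2n1)S(=O)(=O)c1ccc(OC(F)(F)F)cc1` differs from compound 2 by 4-(trifluoromethoxy)phenyl in place of 2,4-dimethoxyphenyl on a sulfonyl sulfur. Among the compounds with values here, only that one step bears on this change; it likewise exchanged the group on the sulfonyl sulfur and left the number within scatter, so the expected step of a 1.4-fold lower number from compound 2 to compound 3 (0.13 log units; within the scatter) is estimated as none beyond the scatter. Compound 3 is therefore expected at 19000 nM, within a range of 7000 nM to 50000 nM.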

Compound 3, half-maximal inhibitory concentration: 8000 nM
Estimate against measurement, compound 3: 2.4-fold (0.38 log units) above, and the stated range covers the measured number.
By their numbers in this assay, from the lowest: compound 3; then compounds 1 and 2 (each within the scatter of the next).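

In this assay, exchanging the group on the sulfonyl sulfur can move the number beyond the scatter: 4-(trifluoromethoxy)phenyl in place of 2,4-dimethoxyphenyl gives a 3.2-fold lower number from compound 2 to compound 3 (0.51 log units; beyond the scatter), and trifluoromethoxy in place of chloro on an aromatic carbon gives a 2.3-fold lower number from compound 1 to compound 3 (0.36 log units; beyond the scatter). Compound 3 therefore has the lowest number of the three, whereas the earlier exchange at this position stayed within the scatter. Nothing available explains this difference. Still open, going by these compounds, is whether an amine or a carboxylic acid in place of trifluoromethoxy on that aromatic carbon would keep the lower number.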